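This account rests on a few compounds, and the source may have more. Where it says the series, first, only, none or still open, it means among the compounds named here.

Measured compounds:
Compound 1 `CN1CCN(c2ccc3[nH]nc(S(=O)(=O)c4ccc(Cl)cc4)c3c2)CC1` – 100%
Compound 2 `CN1CCN(c2cccc3c(S(=O)(=O)c4cccc5ccccc45)n[nH]c23)CC1` – 100%
Compound 3 `CC(C)n1nc(S(=O)(=O)c2cccc3ccccc23)c2cc(N3CCN(C)CC3)ccc21` – 98%

In a functional assay on HeLa cells for antagonist activity at 5-hydroxytryptamine receptor 6 (Homo sapiens) (a higher number here means a larger maximal response, a lower number a smaller maximal response), compound 1 gives 100%, level with compound 2 at the digits shown; compound 3 reaches a value that lies within the scatter of both, so the three measured compounds cannot be told apart on this read-out. The account now turns to compound 4 `COc1cccc(S(=O)(=O)c2n[nH]c3ccc(N4CCN(C)CC4)cc23)c1`, which differs from compound 1 by 3-methoxyphenyl in place of 4-chlorophenyl on a sulfonyl sulfur. Going by the values given here, no step between measured compounds follows this change, and the measured set gives no pair from which a move in the maximal response could be read. The expectation is therefore a step of a number 2 percentage points lower from compound 1 to compound 4 (within the scatter) of no size beyond the scatter, in either direction. For compound 4 the estimate is 98%, within a range from 85% to 100%.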

Compound 4, largest response reached (reported as Imax), in percent of the reference or control that the assay uses: 100%
The estimate for compound 4 lay 2 percentage points below the measured number; low and high end bracket the measured number.
By their numbers in this assay, from the lowest: compounds 3, 1, 2 and 4 (each within the scatter of the next).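

In this assay, 3-methoxyphenyl in place of 4-chlorophenyl on a sulfonyl sulfur gives the only one-place step among the compounds shown: no change at the digits printed from compound 1 to compound 4 (within the scatter). At this position, then, one aromatic ring of carbon can replace the other, with the hydrogen-bond acceptor counted for 3-methoxyphenyl, without a move in the maximal response beyond the scatter. Nothing available explains this result.

From the compounds shown here alone, it remains open whether an amine, a carboxylic acid or a longer chain on that sulfonyl sulfur would hold the maximal response. Since all four numbers lie within the scatter, the compounds shown do not reveal which changes would move it.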